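The compounds below may be only part of what the source reports. "The series", "measured", "known", "first", "only" and "open" are said of these compounds alone.

Among the compounds with values here, compound 3 `CC(Oc1ccc(Oc2ccc(Cl)cc2)cc1)C(=O)Cn1nnc(-c2ccc(C(=O)O)cc2)n1` gives 3.3 in a physicochemical assay for lipophilicity, read by HPLC, tested at 5 mM (a higher number here means a more lipophilic compound, a lower number a more polar compound), and stands second highest of the three numbers measured so far. Nearest is compound 2 `CC(Oc1ccc(Oc2ccc(F)cc2)cc1)C(=O)Cn1nnc(-c2ccc(C(=O)O)cc2)n1`, which in this assay gives 2.7; furthest is compound 1 `CC(Oc1ccc(Oc2ccc(C(F)(F)F)cc2)cc1)C(=O)Cn1nnc(-c2ccccc2)n1`, which in this assay gives 6.2. Compound 4 `CC(Oc1ccc(Oc2ccc(C(F)(F)F)cc2)cc1)C(=O)Cn1nnc(-c2ccc(C(=O)O)cc2)n1` differs from compound 3 by trifluoromethyl in place of chloro on an aromatic carbon. Within the data shown here, no measured step makes exactly this change; the one step that bears on it, a halogen exchange on the same aromatic carbon, went a number 0.60 log units higher from compound 2 to compound 3 (beyond the scatter). Compound 1 carries the trifluoromethyl group but differs from compound 3 in more than one place, so its value shows only that it lies well above compound 3. A modest rise in this assay is therefore expected, a number 0.40 log units higher from compound 3 to compound 4 (beyond the scatter). Compound 4 is estimated at 3.7, with a range from 3.2 to 4.3.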

Compound 4, partition coefficient: 3.5
Compound 4: middle estimate off by 0.20 log units, on the high side; the range from low to high includes it.
By their numbers in this assay, from the lowest: compound 2; then compounds 3 and 4 (each within the scatter of the next); then compound 1.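

In this assay, trifluoromethyl in place of chloro gives a number 0.20 log units higher from compound 3 to compound 4 (within the scatter), so the two groups are not separated at this position, while trifluoromethyl in place of fluoro gives a number 0.80 log units higher from compound 2 to compound 4 (beyond the scatter). With trifluoromethyl held constant, carboxy in place of hydrogen on an aromatic carbon gives a number 2.70 log units lower from compound 1 to compound 4 (beyond the scatter), a much larger step than either exchange at the halogen-bearing position. No supporting data are available to explain these readings. From the compounds shown here alone, it remains open whether a nitrile or methoxy group here would read closer to fluoro or to chloro and trifluoromethyl. Also open, going by these compounds, is whether an amide or amine in place of carboxy would give a step of similar size.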